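Pyridin-4-yl for Phenyl on the Amide of Compound 1

A few compounds are considered here, and "the series" means these few. Any claim that something is new, unique, unknown or untested is made for them only; others in the source may bear on it.

Compound 1 `Cc1nc(NC(=O)c2ccccc2)c2nn(-c3ccccc3)cc2n1` stands highest of the three measured compounds in an assay on CHO cells for displacement of a labelled ligand from adenosine receptor A1 (Homo sapiens), read by scintillation counting, with a stated time of 120 min, tested at 1 uM (on this read-out higher numbers stand for more inhibition at the one concentration tested (going by the name of the read-out) and lower numbers for less inhibition), where compound 1 gives 30%. Compound 2 `COc1ccc(-n2cc3nc(-c4ccccc4)nc(N)c3n2)cc1` gives 12% in this assay, and compound 3 `Cc1nc(N(C(=O)c2ccccc2)C(=O)c2ccccc2)c2nn(-c3ccccc3)cc2n1` gives 6%; both of these gaps from compound 1 lie beyond the scatter. Within the data shown here, the only measured step that changes a single place is a number 24 percentage points lower from compound 1 to compound 3 (beyond the scatter), an alteration at the amide-type nitrogen rather than at the carbonyl carbon. Compound 4 `Cc1nc(NC(=O)c2ccncc2)c2nn(-c3ccccc3)cc2n1` differs from compound 1 by pyridin-4-yl in place of phenyl on a carbonyl carbon. Among the measured compounds shown here, no measured step exchanges the ring on the carbonyl carbon, so the move to compound 4 has no direct counterpart among the measured steps, and the step from compound 1 to compound 3 bears on it only loosely. The account therefore expects compound 4 to remain near compound 1, with a step of a number 5 percentage points lower from compound 1 to compound 4 (within the scatter) that is not expected to exceed the scatter. The estimate for compound 4 is 25%, expected to lie between 8% and 45%.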

Compound 4, a percentage reported as inhibition, at one concentration (the size of the read-out at that concentration, not a potency): 12%
The estimate for compound 4 lay 13 percentage points above the measured number, and the stated range covers the measured number.
By their numbers in this assay, from the lowest: compounds 3, 2 and 4 (each within the scatter of the next); then compound 1.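

The ring on the carbonyl carbon proves to be a place that responds in this assay: a number 18 percentage points lower from compound 1 to compound 4 (beyond the scatter). Among these compounds, until now, the only single-place change measured was at the amide-type nitrogen, whereas this change keeps that nitrogen and its hydrogen and swaps one six-membered aromatic ring for another of the same heavy-atom count, with one ring carbon replaced by nitrogen and a hydrogen-bond acceptor gained. No evidence available here explains the drop. On these data alone, what remains open is whether a ring nitrogen at any other point of this ring would give a similar step, and how a cyclohexyl ring or a plain methyl on the carbonyl carbon would compare with phenyl. With a single replacement at this place, the compounds shown give no trend across groups on the carbonyl carbon.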